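A Chloro Step from Compound 1 to Compound 4

This account rests on a few compounds, and the source may have more. Where it says the series, first, only, none or still open, it means among the compounds named here.

Compound 1 (`COc1ccc(C2CC(c3ccccc3)=NN2c2nc(-c3ccccc3)c(C#N)c(=O)n2C)cc1`) stands lowest of the three measured compounds in a functional assay on A549 cells (Homo sapiens) for antiproliferative activity, with a stated time of 72 h (a higher number here means a weaker inhibitor, a lower number a stronger inhibitor), with 1760 nM as its value. Compound 2 (`COc1ccc(C2CC(c3ccc(Cl)cc3)=NN2c2nc(-c3ccccc3)c(C#N)c(=O)n2C)cc1`) gives 6070 nM and compound 3 (`COc1ccc(C2=NN(c3nc(-c4ccccc4)c(C#N)c(=O)n3C)C(c3ccc(OC)cc3)C2)cc1`) gives 26500 nM in the same test. Compound 4 (`COc1ccc(C2CC(c3ccccc3)=NN2c2nc(-c3ccc(Cl)cc3)c(C#N)c(=O)n2C)cc1`), not yet measured, differs from compound 1 by one change (chloro in place of hydrogen on an aromatic carbon), phenyl to 4-chlorophenyl. Going by the values given here, the closest precedent is the same exchange made elsewhere in the molecule (a 3.4-fold higher number from compound 1 to compound 2 (0.54 log units; beyond the scatter)), a modest step beyond the scatter. The methoxy exchange (a 15-fold higher number from compound 1 to compound 3 (1.18 log units; beyond the scatter)) was large but bears less directly. A modest step to a higher number is therefore expected (a 2.0-fold higher number from compound 1 to compound 4 (0.30 log units; within the scatter)) here. Compound 4 is estimated near 3500 nM with an expected range from 1200 nM to 10000 nM for its value.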

Compound 4, half-maximal inhibitory concentration: 23800 nM
Compound 4: the middle estimate sits 6.8-fold (0.83 log units) below what was measured; measured number outside the range, above it.
By their numbers in this assay, from the lowest: compound 1; then compound 2; then compounds 4 and 3 (each within the scatter of the next).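

On this phenyl, the chloro exchange gives a large step (a 14-fold higher number from compound 1 to compound 4 (1.13 log units; beyond the scatter)), whereas the same exchange made elsewhere in the molecule gave a modest one (a 3.4-fold higher number from compound 1 to compound 2 (0.54 log units; beyond the scatter)). In this assay, the size of the penalty for this single chlorine therefore depends on which aromatic ring carries it, and this ring tolerates it poorly. Nothing available explains the loss.

The compounds shown leave open whether the loss is specific to chloro or follows any replacement of this hydrogen. A fluoro, an amine or a carboxylic acid at this position would separate those readings.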